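This account rests on a few compounds, and the source may have more. Where it says the series, first, only, none or still open, it means among the compounds named here.

In a functional assay on MCF7 cells (Homo sapiens) for antiproliferative activity (on this read-out higher numbers stand for weaker inhibition of growth and lower numbers for stronger inhibition of growth), compound 2 `O=C(NO)c1cnc(N2CCN(S(=O)(=O)c3ccccc3)CC2)s1` gives 10000 nM, the highest number among the three measured compounds. Its nearest neighbour is compound 3 `O=C(NO)c1cnc(N2CCN(S(=O)(=O)c3ccc(F)cc3)CC2)s1`, which gives 3500 nM; the furthest is compound 1 `O=C(NO)c1cnc(N2CCN(S(=O)(=O)c3ccc(-c4ccccc4)cc3)CC2)s1`, which gives 1800 nM. The measured steps concern only the aryl group on the sulfonyl: a 5.6-fold higher number from compound 1 to compound 2 (0.74 log units; beyond the scatter) and a 2.9-fold lower number from compound 2 to compound 3 (0.46 log units; beyond the scatter), while a 1.9-fold higher number from compound 1 to compound 3 (0.29 log units; within the scatter).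

Compound 4 `O=C(/C=C/c1cnc(N2CCN(S(=O)(=O)c3ccccc3)CC2)s1)NO` differs from compound 2 at the other end of the shared core: 2-(hydroxycarbamoyl)ethenyl in place of hydroxycarbamoyl on an aromatic carbon. Going by the values given here, this change sits on an aromatic carbon of the five-membered aromatic ring with one nitrogen and one sulfur, next to the ring sulfur, and no measured step touches that position. The three steps described above therefore do not bear on it, and they offer no guide to its direction or size; the two-carbon extension is new to this set.

Among the compounds with values here, with no step to rest on, the expectation for compound 4 in this assay starts from compound 2 and is estimated as a 2.5-fold lower number from compound 2 to compound 4 (0.40 log units; beyond the scatter), with the range kept wide. Compound 4 is expected to give about 4000 nM in this assay, between 700 nM and 22000 nM.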

Compound 4, concentration for 50% growth inhibition: 3000 nM
Estimate against measurement, compound 4: 1.3-fold (0.12 log units) above, within the range that was stated.
By their numbers in this assay, from the lowest: compounds 1, 4 and 3 (each within the scatter of the next); then compound 2.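

In this assay, placing 2-(hydroxycarbamoyl)ethenyl in place of hydroxycarbamoyl on the aromatic carbon next to the ring sulfur gives a 3.3-fold lower number from compound 2 to compound 4 (0.52 log units; beyond the scatter), so the longer group is accompanied by stronger inhibition of growth rather than a loss of it. Going by these compounds alone, the earlier compounds varied only the aryl group on the sulfonyl, and this step is the first to show that the read-out also responds to a change at the other end of the shared core. Nothing available accounts for the size or direction of this step, so it stands as an observation from a single pair of compounds.

The compounds shown leave open whether the same change would lower the number when the sulfonyl aryl group carries fluoro or phenyl, since this position is compared only with an unsubstituted phenyl on the sulfonyl. From the compounds shown here alone, it also remains open how a saturated 2-(hydroxycarbamoyl)ethyl group, a longer chain ending in hydroxycarbamoyl, or a carboxylic acid in place of the hydroxycarbamoyl would read at this position.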